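The compounds below may be only part of what the source reports. "The series", "measured", "known", "first", "only" and "open" are said of these compounds alone.

In an ADME assay on microsomes from liver (Homo sapiens) for metabolic stability, read by LC-MS, with a stated time of 10 min (a lower number here means that less of the compound is left, a higher number that more of the compound is left), the measured compounds read as follows:
Compound 1 `CN(C[C@@H]1Cc2c(cccc2N2CCNCC2)CN1)[C@H]1CCCc2cccnc21` (94.2%)
Compound 2 `CN(C[C@H]1Cc2c(cccc2N2CCNC(C)(C)C2)CN1)[C@H]1CCCc2cccnc21` (100%)
Compound 3 `FC1(F)CCC(CN(C[C@H]2Cc3c(cccc3N3CCNCC3)CN2)[C@H]2CCCc3cccnc32)CC1` (68.6%)

Compound 2 (100%) lies within the scatter of compound 1 (94.2%) and clearly above compound 3 (68.6%). Compound 4 `CN(C[C@H]1Cc2c(cccc2N2CCN3CCC[C@@H]3C2)CN1)[C@H]1CCCc2cccnc21` keeps the core of compound 2 but replaces the 3,3-dimethylpiperazin-1-yl group on an aromatic carbon with a group of one five-membered and one six-membered non-aromatic ring a group of 9 heavy atoms (7 carbon, 2 nitrogen; one five-membered non-aromatic ring with 1 hetero atom, one six-membered non-aromatic ring with 2 hetero atoms) in place of a group of 8 heavy atoms (6 carbon, 2 nitrogen; one six-membered non-aromatic ring with 2 hetero atoms), on an aromatic carbon and is still unmeasured. Among the compounds with values here, no measured pair isolates this change. Still, compound 1 carries a different group at this place and stays within the scatter of compound 2 in this assay. Only a small fall is expected, and a number 10 percentage points lower from compound 2 to compound 4 (within the scatter) is estimated to stay close to the scatter. For compound 4 the estimate is 90% (expected range 72% to 100%).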

Compound 4, percent of the compound remaining: 52.2%
Estimate against measurement, compound 4: 37.8 percentage points above; measured number below the stated range.
By their numbers in this assay, from the lowest: compound 4; then compound 3; then compounds 1 and 2 (each within the scatter of the next).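

In this assay the group at this aromatic carbon proves able to move the read-out strongly: exchanging 3,3-dimethylpiperazin-1-yl for the group with one five-membered and one six-membered non-aromatic ring gives a number 47.8 percentage points lower from compound 2 to compound 4 (beyond the scatter) in a single step. The earlier compounds shown here offered no pair that isolated this place. Nothing available accounts for the fall.

This one step does not separate the added ring, the lost hydrogen-bond donor and the new stereocentre. As far as these compounds go, how a methylpiperazine or a morpholine would read at this place stays open.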